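The compounds below may be only part of what the source reports. "The series", "measured", "known", "first", "only" and "open" are said of these compounds alone.

Measured in a functional assay on MDA-MB-231 cells (Homo sapiens) for antiproliferative activity, read by sulforhodamine B assay, with a stated time of 48 h (on this read-out lower numbers stand for stronger inhibition and higher numbers for weaker inhibition), so far:
compound 1 `CCc1cccc(NS(=O)(=O)c2ccc(N3CCNC3=O)cc2)c1` gives 1410 nM
compound 2 `COc1cc(NS(=O)(=O)c2ccc(N3CCNC3=O)cc2)cc(OC)c1OC` gives 45 nM

Of these two, compound 1 holds the higher number and so the weaker inhibition, and its gap to compound 2 lies beyond the scatter. Next in the series is compound 3 `Cc1cc(C)cc(NS(=O)(=O)c2ccc(N3CCNC3=O)cc2)c1` which has the same atoms as compound 1, joined differently. The change 3,5-dimethylphenyl in place of 3-ethylphenyl on a sulfonamide nitrogen puts 3,5-dimethylphenyl in place of 3-ethylphenyl on a sulfonamide nitrogen. Among the measured compounds shown here, no measured pair shows a step of this kind. For the measured compounds named here, the only guide is that compound 2, with another group on that nitrogen, gives 45 nM as its value. A moderate move toward lower numbers in this assay is therefore expected, possibly not far beyond the scatter. a 2.4-fold lower number from compound 1 to compound 3 (0.37 log units; beyond the scatter) is the step expected here. For compound 3 the estimated value is 600 nM with 150 nM to 2400 nM as the expected range.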

Compound 3, half-maximal inhibitory concentration: 1220 nM
For compound 3 the middle estimate is 2.0-fold (0.31 log units) below the measured one; measured number inside the range.
By their numbers in this assay, from the lowest: compound 2; then compounds 3 and 1 (each within the scatter of the next).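

In this assay the exchange of 3-ethylphenyl for 3,5-dimethylphenyl on a sulfonamide nitrogen is a 1.2-fold lower number from compound 1 to compound 3 (0.06 log units; within the scatter) and so gives no separation that this read-out can resolve. With the same atoms joined differently, one ethyl group and two methyl groups on the phenyl ring read alike at this position. No measurement at hand bears on why these two groups read alike.

Open, from the compounds shown here alone, is whether a longer chain such as propyl, or an amine or a carboxylic acid on the phenyl ring, would also read alike. Also open is what in the substitution of compound 2 at 45 nM accounts for that value, a question that a phenyl ring carrying a single methoxy group could help to answer.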